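A few compounds are considered here, and "the series" means these few. Any claim that something is new, unique, unknown or untested is made for them only; others in the source may bear on it.

Measured so far in a functional assay on HOS-TE85 cells (Homo sapiens) for inhibition, read by CCK-8 assay, with a stated time of 72 h; a higher number here means a weaker inhibitor, a lower number a stronger inhibitor:
- compound 1 `O=C(NCCCCc1ccccc1)c1cc(F)cc(C2SCC(=O)N2c2ccccn2)c1` gives 14.2 nM
- compound 2 `COc1ccc(F)cc1N1C(=O)CSC1c1cccc(C(=O)NCCCCc2ccccc2)c1` gives 8.8 nM

Compound 2 stands within the usual scatter of compound 1, so these two values give no ranking. The next compound in the series is compound 3 `O=C(NCCCCc1ccccc1)c1cccc(C2SCC(=O)N2c2ccccn2)c1`, which differs from compound 2 in one place: pyridin-2-yl in place of 5-fluoro-2-methoxyphenyl on an amide-type nitrogen in a ring. For the measured compounds named here, no step between measured compounds is available to size this change directly. Going by the values given here, the only guide is compound 1, which also carries pyridin-2-yl in that place and gives 14.2 nM in this assay, a value within the scatter of compound 2, which gives 8.8 nM. The shift expected in this assay is therefore none beyond the scatter, with no firm direction. The estimated move is a 1.5-fold higher number from compound 2 to compound 3 (0.17 log units; within the scatter), and the uncertainty around it remains wide. For compound 3 the estimated value is 13 nM, with an expected range from 5 nM to 35 nM.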

Compound 3, half-maximal inhibitory concentration: 19.7 nM
Compound 3: the middle estimate sits 1.5-fold (0.18 log units) below what was measured; low and high end bracket the measured number.
By their numbers in this assay, from the lowest: compounds 2, 1 and 3 (each within the scatter of the next, the first and the last beyond it).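

In this assay, for the compounds shown here, pyridin-2-yl in place of 5-fluoro-2-methoxyphenyl on the amide-type nitrogen in the ring gives a 2.2-fold higher number from compound 2 to compound 3 (0.35 log units; beyond the scatter), the first direct reading of this change: a modest step, but one beyond the scatter, so the group at this position does register in the assay. Hydrogen in place of fluoro on an aromatic carbon gives a 1.4-fold higher number from compound 1 to compound 3 (0.14 log units; within the scatter), which lies within the scatter, so with pyridin-2-yl at the ring nitrogen this fluoro has no measurable effect on the number. No measurement here bears on why the group on the ring nitrogen shifts the value.

Still open, as far as these compounds go, is whether the methoxy or the fluoro of 5-fluoro-2-methoxyphenyl accounts for the step, and how a plain phenyl, a pyridin-3-yl or a pyridin-4-yl would read on the same nitrogen. Also open, from the compounds shown here alone, is whether the series tolerates a carboxylic acid or a morpholine on the aromatic ring that bears the amide, since only hydrogen and fluoro appear on that ring in these compounds.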